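The compounds below may be only part of what the source reports. "The series", "measured", "known", "first", "only" and "open" are said of these compounds alone.

Compound 1, `Cn1c(=O)c2[nH]c(SCC(=O)c3ccccc3)nc2n(C)c1=O`, is the reference point of this small set. In a functional assay on PANC-1 cells (Homo sapiens) for inhibition, read by MTT assay, with a stated time of 48 h (a higher number here means a weaker inhibitor, a lower number a stronger inhibitor), compound 1 gives 4900 nM. Compound 2, `COc1ccc(C(=O)CSc2nc3c([nH]2)c(=O)n(C)c(=O)n3C)cc1`, differs from compound 1 in a single place: methoxy in place of hydrogen on an aromatic carbon. In this assay compound 2 gives 6400 nM, and the step is a 1.3-fold higher number from compound 1 to compound 2 (0.12 log units; within the scatter). Compound 3, `Cn1c(=O)c2[nH]c(SC/C(=N/O)c3ccccc3)nc2n(C)c1=O`, carries a different core from compound 1; the difference between the two cores is not broken down here. In this assay compound 3 gives 5500 nM, a number that sits within the scatter of both compound 1 and compound 2.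

Compound 4, `COc1ccc(/C(CSc2nc3c([nH]2)c(=O)n(C)c(=O)n3C)=N\O)cc1`, has not yet been measured. It differs from compound 3 by methoxy in place of hydrogen on an aromatic carbon, the same change that was made from compound 1 to compound 2, at the same place, para to a large group. Among the compounds shown this change occurs twice in all, and only one instance carries a measurement. That single measured instance, a 1.3-fold higher number from compound 1 to compound 2 (0.12 log units; within the scatter), moved the number only within the scatter, and the expectation for the second instance rests on it. The step is therefore expected to be of about the same size, a 1.3-fold higher number from compound 3 to compound 4 (0.10 log units; within the scatter). The estimate for compound 4 in this assay is 7000 nM. The likely range for compound 4 runs from 3500 nM to 14000 nM.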

Compound 4, half-maximal inhibitory concentration: 910 nM
Estimate against measurement, compound 4: 7.7-fold (0.89 log units) above; the measured number lies below the stated range.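

In this assay, methoxy in place of hydrogen on the aromatic carbon para to a large group gives a 6.0-fold lower number from compound 3 to compound 4 (0.78 log units; beyond the scatter), while the same phenyl to 4-methoxyphenyl change on the core of compound 1 gives a 1.3-fold higher number from compound 1 to compound 2 (0.12 log units; within the scatter), a step that stays within the scatter. The size of the step measured on one of these cores therefore did not carry over to the other, and the two steps differ by more than their combined uncertainty allows: the same change on two cores in this assay, a 1.3-fold higher number (0.12 log units; within the scatter) from compound 1 to compound 2 and a 6.0-fold lower number (0.78 log units; beyond the scatter) from compound 3 to compound 4, 7.9-fold (0.90 log units) apart, beyond the scatter of two such steps What this does not show is which part of the difference between the two cores goes with the gap, why the steps part, or how the change would behave on any further core, since each core contributes a single pair of compounds.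

The compounds shown hold only hydrogen and methoxy on this ring, so it remains open whether an ethoxy group, a hydroxyl group or a chlorine atom at the same place would also give a lower number on the core of compound 3 than on the core of compound 1. As far as these compounds go, only the place para to a large group is represented, so the effect of a methoxy group elsewhere on the ring also remains open.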